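Hydroxy in Place of Trifluoromethyl: An Expected Loss

The compounds below may be only part of what the source reports. "The series", "measured", "known", "first", "only" and "open" are said of these compounds alone.

Compound 1 `O=C(Nc1ccc(C(F)(F)F)cc1)C1CCc2ccccc2N1` gives 24200 nM in a functional assay on MDA-MB-231 cells (Homo sapiens) for cytotoxicity, read by sulforhodamine B assay, with a stated time of 72 h; on this read-out lower numbers stand for stronger inhibition of growth and higher numbers for weaker inhibition of growth. Compound 3 `O=C(Nc1ccc(O)cc1)C1CCc2ccccc2N1` reaches only a limit in this assay, > 100000 nM, namely (the limit of > 100000 nM in this assay, at which 1 of the 3 values shown sits). The change hydroxy in place of trifluoromethyl on an aromatic carbon therefore produced an at least 4.1-fold higher number from compound 1 to compound 3 (0.61 log units; beyond the scatter). Compound 2 `CCCCCCCCC(=O)N1c2ccccc2CCC1C(=O)Nc1ccccc1C(F)(F)F` gives 3350 nM in this assay; the difference between the core of compound 2 and the core of compound 1 is not broken down here. Compound 4 `CCCCCCCCC(=O)N1c2ccccc2CCC1C(=O)Nc1ccccc1O` has not yet been measured and differs from compound 2 by hydroxy in place of trifluoromethyl on an aromatic carbon; the place differs, ortho to a large group here and para to a large group in compound 3, so this is the same kind of change. A weakening like an at least 4.1-fold higher number from compound 1 to compound 3 (0.61 log units; beyond the scatter) is expected, so for compound 4 the estimated step is a 6.0-fold higher number from compound 2 to compound 4 (0.78 log units; beyond the scatter). Compound 4 is thus estimated at 20000 nM, between 6000 nM and 80000 nM.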

Compound 4, concentration for 50% growth inhibition: 54300 nM
Compound 4: middle estimate off by 2.7-fold (0.43 log units), on the low side, and the stated range covers the measured number.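

In this assay hydroxy in place of trifluoromethyl again weakened the inhibition of growth, with a 16-fold higher number from compound 2 to compound 4 (1.21 log units; beyond the scatter). The value of compound 3, > 100000 nM, is a limit and not a number. The direction of the change therefore held on both cores in the two pairs shown, but this does not establish that the size of the step carries over from one core to the other: the same change on two cores in this assay, an at least 4.1-fold higher number (0.61 log units; beyond the scatter) from compound 1 to compound 3 and a 16-fold higher number (1.21 log units; beyond the scatter) from compound 2 to compound 4; the limit leaves it open whether they differ

The compounds shown leave open whether an amine or a carboxylic acid in the same place would weaken growth inhibition as hydroxy does. Going by these compounds alone, they also leave open whether a longer chain than the one in compound 4 would alter the size of this step.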